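Dropping the 4-aminobutyl chain: compound 3 to compound 4

This account rests on a few compounds, and the source may have more. Where it says the series, first, only, none or still open, it means among the compounds named here.

Three close relatives sharing one core have been tested in a functional assay on the whole organism (Tail, strain ICR) with Mus musculus as the target, in the tail flick test, with a stated time of 90 min, at a dose of 25 umol/kg by the oral route; on this read-out lower numbers stand for a weaker effect and higher numbers for a stronger effect at the one dose given. Compound 1 `O=C(CN(c1nc(Cl)nc2[nH]cnc12)C1CC1)NCC(=O)OCc1ccccc1` gives 27.2%. Compound 2 `NC(=O)CC[C@H](NC(=O)CN(c1nc(Cl)nc2[nH]cnc12)C1CC1)C(=O)O` gives 41.1%. Compound 3 `NCCCC[C@H](NC(=O)CN(c1nc(Cl)nc2[nH]cnc12)C1CC1)C(=O)O` gives 28.8%. On these numbers compound 3 stands second highest of the three: compound 2 lies above it beyond the scatter, while compound 1 sits close enough that the two cannot be told apart.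

Compound 4 `O=C(O)CNC(=O)CN(c1nc(Cl)nc2[nH]cnc12)C1CC1` has not yet been measured in this assay. It differs from compound 3 in one place: hydrogen in place of 4-aminobutyl on a saturated chain carbon bound to an amide-type nitrogen and a carbonyl carbon. Among the compounds with values here, only one measured step bears on such a change at that position, a number 12.3 percentage points lower from compound 2 to compound 3 (beyond the scatter), which swapped one group for another on the same carbon rather than removing a group entirely. Within the data shown here, no measured step shows what removing the 4-aminobutyl chain does. That the values of compound 1 and compound 3 lie within the scatter of each other, despite a different group at the end of the chain, suggests the read-out in this assay is not very sensitive to what hangs there.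

Compound 4 is therefore expected to show a step of a number 1.8 percentage points lower from compound 3 to compound 4 (within the scatter), likely within the scatter. The estimate for compound 4 is 27%, with a range from 14% to 40%.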

Compound 4, a percentage reported as activity, at one dose (the size of the read-out at that dose, not a potency): 32.3%
Compound 4: the middle estimate sits 5.3 percentage points below what was measured; the range from low to high includes it.
By their numbers in this assay, from the lowest: compounds 1, 3, 4 and 2 (each within the scatter of the next, the first and the last beyond it).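

In this assay, taking the 4-aminobutyl chain off this carbon altogether gives a number 3.5 percentage points higher from compound 3 to compound 4 (within the scatter), so the read-out does not depend measurably on that chain. Removing the other side chain gives a number 8.8 percentage points lower from compound 2 to compound 4 (within the scatter), which shows something the earlier step could not: compound 2 and compound 3 lie beyond the scatter of each other, yet neither can be told apart from compound 4, which carries only hydrogen on this carbon, so the gap between them cannot be assigned to either side chain alone. At the other end of the molecule, hydrogen in place of benzyl on an oxygen next to a carbonyl group gives a number 5.1 percentage points higher from compound 1 to compound 4 (within the scatter), so the free acid and the benzyl ester cannot be told apart either.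

Nothing in the data given explains why the values fall as they do. Still open, from the compounds shown here alone, is whether a methyl group, or a side chain ending in a carboxylic acid, on this same carbon would stand clear of hydrogen beyond the scatter, since all these comparisons rest on one dose and one time point.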